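Lengthening the Amide Chain: Expected Cytotoxicity of Compound 4

The source may report more compounds than this note shows. Statements on the series, on what has been measured and on what is new or still open speak of the compounds shown alone.

Three compounds built on one shared core have been examined in an ADME assay on MT2 cells (Homo sapiens) for cytotoxicity; on this read-out higher numbers stand for lower toxicity in this test and lower numbers for higher toxicity in this test. Compound 1, `Cc1nc2cc(C(=O)NCc3ccc(F)c(C4CC4)c3)nn2c(-c2cc(F)c3c(c2C)CCCO3)c1[C@H](OC(C)(C)C)C(=O)O`, carries a 3-cyclopropyl-4-fluorophenyl group on a saturated chain carbon bound to an amide-type nitrogen. In this assay compound 1 reaches only the limit of > 40000 nM. Compound 2, `Cc1nc2cc(C(=O)NCCC(C)(C)C)nn2c(-c2cc(F)c3c(c2C)CCCO3)c1[C@H](OC(C)(C)C)C(=O)O`, bears neopentyl at that position. In this assay compound 2 likewise returns the limit of > 40000 nM. Compound 3, `Cc1nc2cc(C(=O)NCC3CCOCC3)nn2c(-c2cc(F)c3c(c2C)CCCO3)c1[C@H](OC(C)(C)C)C(=O)O`, has oxan-4-yl there. In this assay compound 3 also gives the limit of > 40000 nM. Among the measured compounds shown here, because every value sits at the limit recorded in the limit of > 40000 nM in this assay, at which 3 of the 3 values shown sit, the steps a step that the two limits leave unreadable from compound 1 to compound 2, a step that the two limits leave unreadable from compound 1 to compound 3 and a step that the two limits leave unreadable from compound 2 to compound 3 cannot be sized, and compound 3 stands simply among the others at the limit, no compound being separable from any other.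

Compound 4, `Cc1nc2cc(C(=O)NCCC3CCOCC3)nn2c(-c2cc(F)c3c(c2C)CCCO3)c1[C@H](OC(C)(C)C)C(=O)O`, differs from compound 3 in one place: (oxan-4-yl)methyl in place of oxan-4-yl on a saturated chain carbon bound to an amide-type nitrogen. For the measured compounds named here, no measured step is readable, so none gives a direction for this change; the three values show only that nothing so far has produced a measurable half-maximal cytotoxic concentration. Compound 4 is therefore expected to behave like compound 3, with an estimated step that the limit leaves unreadable from compound 3 to compound 4. For compound 4 the expected value is 50000 nM, in the range 30000 nM to 100000 nM, most likely again reported as a limit.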

Compound 4, half-maximal cytotoxic concentration: > 40000 nM
Compound 4: only a limit was reported; the forecaster's own chance of this, stated with the estimate: 85%; the middle value does not contradict the limit.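

In this assay compound 4 gives > 40000 nM, which is a limit, so no new step can be read from compound 1, compound 2 or compound 3 to compound 4: the limit of > 40000 nM in this assay, at which 4 of the 4 values shown sit.

The four compounds leave open whether they differ from one another at all on this read-out, and which change to the amide chain, if any, would give a measurable half-maximal cytotoxic concentration.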